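The source may hold more compounds than are shown below. What is called first, only, known or untested is meant among the compounds shown, and "the series" means these compounds.

Compound 3, `Brc1ccc(Oc2ccc(/C=N/Nc3nc4ccccc4s3)cc2)cc1`, stands lowest of the three numbers in a physicochemical assay for lipophilicity, in phosphate buffer, measured as octanol-water partition, with a stated time of 24 h; on this read-out lower numbers stand for lower lipophilicity and higher numbers for higher lipophilicity: compound 3 gives 5.5. Its nearest neighbour is compound 1, `O=C(CSc1nc2ccccc2s1)N/N=C/c1ccc(Oc2ccccc2)cc1`, which in this assay gives 5.6, and the furthest is compound 2, `Cc1ccc(Oc2ccc(/C=N/NC(=O)CSc3nc4ccccc4s3)cc2)cc1`, which gives 5.7; both gaps to compound 3 lie within the scatter. Compound 4, `Cc1cc(Oc2ccc(/C=N/Nc3nc4ccccc4s3)cc2)ccc1Cl`, differs from compound 3 in one place: 4-chloro-3-methylphenyl in place of 4-bromophenyl on an oxygen on an aromatic ring. Among the compounds with values here, only one measured step bears on it, and only in part. That step, a number 0.10 log units higher from compound 1 to compound 2 (within the scatter), shows methyl in place of hydrogen on an aromatic carbon and is within the scatter. Within the data shown here, no measured pair shows chlorine in place of bromine, so that part of the change rests on nothing measured here. Among the measured compounds shown here, because the one related step of a number 0.10 log units higher from compound 1 to compound 2 (within the scatter) was small, compound 4 is expected to show a step of a number 0.30 log units higher from compound 3 to compound 4 (within the scatter) in this assay, upward but modest. Compound 4 is therefore estimated at 5.8 in this assay, with a range from 5.4 to 6.2.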

Compound 4, partition coefficient: 5.5
Beside the measured number, compound 4's estimate is 0.30 log units above it; measured number inside the range.
By their numbers in this assay, from the lowest: compounds 3, 4, 1 and 2 (each within the scatter of the next).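

Exchanging the 4-bromophenyl on an oxygen on an aromatic ring for 4-chloro-3-methylphenyl gives no change at the digits printed from compound 3 to compound 4 (within the scatter) in this assay. Within the data shown here, the earlier compounds offered no pair that differed in this group, so this is the first measured exchange of the halogen-bearing ring on the core of compound 3. With one heavy atom more in the entering group, this read-out still does not separate the two compounds. Nothing among the data offered here accounts for this result.

The step covers the halogen exchange and the added methyl together, so the part each contributes remains unresolved. Also open, as far as these compounds go, is how the read-out would respond with an amine or a carboxylic acid on this ring in place of the halogen, on the core of compound 3.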